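This account rests on a few compounds, and the source may have more. Where it says the series, first, only, none or still open, it means among the compounds named here.

Compound 1 `Oc1cccc(-c2cc(-c3ccc(Cl)cc3)nc(-c3cccs3)c2)c1`: 11800 nM
Compound 2 `Oc1ccc(-c2cc(-c3cccc(Cl)c3)nc(-c3cccs3)c2)cc1`: 2720 nM
Compound 3 `Oc1cccc(-c2cc(-c3ccsc3)nc(-c3cccc(Cl)c3)c2)c1`: 3180 nM

In an ADME assay on HEK293 cells (Homo sapiens) for cytotoxicity, read by CCK-8 assay and cell counting, with a stated time of 2 days (a lower number here means a stronger inhibitor, a higher number a weaker inhibitor), compound 3 gives 3180 nM, the second highest of the three numbers. Compound 2 lies nearest, within the scatter, so no order between the two can be read. Compound 1 stands furthest, with a number higher than that of compound 3 by more than the scatter. Compound 4 `Oc1cccc(-c2cc(-c3cccc(Cl)c3)nc(-c3cccs3)c2)c1` differs from compound 3 in a single place: thiophen-2-yl in place of thiophen-3-yl on an aromatic carbon. Among the compounds with values here, no measured pair shows this change alone, so its size cannot be taken from the data. The step from compound 3 to compound 4 is expected to be small, most likely none beyond the scatter, with no clear direction. Compound 4 is therefore estimated at 3500 nM, in a range from 1400 nM to 9000 nM. This estimate means an expected step of a 1.1-fold higher number from compound 3 to compound 4 (0.04 log units; within the scatter).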

Compound 4, half-maximal inhibitory concentration: 3150 nM
For compound 4 the middle estimate is 1.1-fold (0.05 log units) above the measured one; the measured number falls inside the stated range.
By their numbers in this assay, from the lowest: compounds 2, 4 and 3 (each within the scatter of the next); then compound 1.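

In this assay, thiophen-2-yl in place of thiophen-3-yl next to the ring nitrogen gives a 1.0-fold lower number from compound 3 to compound 4 (0.00 log units; within the scatter), so the two thiophene attachments cannot be told apart at this position. Within the data shown here, the placing of the other substituents reads differently: 3-hydroxyphenyl in place of 4-hydroxyphenyl gives a 1.2-fold higher number from compound 2 to compound 4 (0.06 log units; within the scatter), also no readable change, whereas 3-chlorophenyl in place of 4-chlorophenyl gives a 3.7-fold lower number from compound 1 to compound 4 (0.57 log units; beyond the scatter), the one new step beyond the scatter. Nothing given here explains these steps. The compounds shown leave open whether an amine or a carboxylic acid in place of the hydroxyl group would move the number. They also leave open whether furan-2-yl in place of thiophen-2-yl would stay within the scatter.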